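The compounds below may be only part of what the source reports. "The series", "measured", "known", "first", "only" and "open" are said of these compounds alone.

Measured compounds:
compound 1, `CC(C)C[C@H](NC(=O)[C@H](C)NC(=O)CC[C@H](NS(=O)(=O)c1ccc(Cl)c(C(F)(F)F)c1)C(=O)O)C(=O)N[C@@H](C)C(N)=O` — 1700 nM
compound 2, `CSCC[C@H](NC(=O)[C@H](CC(C)C)NC(=O)[C@H](C)NC(=O)CC[C@H](NS(=O)(=O)c1ccc(Cl)c(C(F)(F)F)c1)C(=O)O)C(N)=O` — 440 nM

In an assay on isolated protein for inhibition of Matrilysin (Homo sapiens), read by fluorescence, with a stated time of 15 min (a lower number here means a stronger inhibitor, a higher number a weaker inhibitor), compound 2 gives 440 nM and stands lowest of the two numbers; compound 1 gives 1700 nM. Going by the values given here, the single measured step, a 3.9-fold lower number from compound 1 to compound 2 (0.59 log units; beyond the scatter), comes from (methylsulfanyl)methyl in place of hydrogen at a different chain position from the one now in question, so it bears on the present change only loosely, as a sign that the chain accepts added groups without loss.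

Compound 3, `CSCC[C@H](NC(=O)[C@H](CC(C)C)NC(=O)[C@H](CC(N)=O)NC(=O)CC[C@H](NS(=O)(=O)c1ccc(Cl)c(C(F)(F)F)c1)C(=O)O)C(N)=O`, differs from compound 2 by carbamoyl in place of hydrogen on a saturated chain carbon, two bonds along the chain from an amide-type nitrogen and a carbonyl carbon. Among the compounds with values here, no measured pair touches this position, so the direction is not fixed by the data. Working from the tolerance shown by compound 2 with 440 nM, the step is expected to be small, about a 1.1-fold lower number from compound 2 to compound 3 (0.04 log units; within the scatter). The estimate for compound 3 in this assay is 400 nM, with a range of 130 nM to 1300 nM.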

Compound 3, half-maximal inhibitory concentration: 7500 nM
For compound 3 the middle estimate is 19-fold (1.27 log units) below the measured one, and the stated range ends below it.
By their numbers in this assay, from the lowest: compound 2; then compound 1; then compound 3.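

In this assay, this chain carbon does not accept every added group: carbamoyl in place of hydrogen, which is the same difference as methyl to carbamoylmethyl, gives a 17-fold higher number from compound 2 to compound 3 (1.23 log units; beyond the scatter). The earlier step, at a different chain position, went toward a lower number, whereas this first measured change at the present position goes the other way by a large margin, so what held at one chain position does not carry over to this one. Nothing available explains the rise in the number.

The compounds shown hold a single replacement at this position, so it remains open whether the rise belongs to carbamoylmethyl specifically or to any group larger than methyl. An ethyl chain, a carboxylic acid or an amine on the same carbon would help separate these two readings.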